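The compounds below may be only part of what the source reports. "The series", "measured", "known", "first", "only" and "open" are said of these compounds alone.

Compound 1 `Nc1nc(-c2ccccc2)cn1/N=C/c1cc2ccccc2nc1Cl` is assessed in a functional assay on DLD-1 cells (Homo sapiens) for cytotoxicity, read by MTT assay, with a stated time of 48 h (a lower number here means a stronger inhibitor, a higher number a weaker inhibitor), where compound 1 gives 16400 nM. Compound 2 `Cc1ccc(-c2cn(/N=C/c3cc4ccccc4nc3Cl)c(N)n2)cc1` carries methyl in place of hydrogen on an aromatic carbon. In this assay compound 2 gives > 50000 nM, which is a limit of the assay rather than a number. That change brings an at least 3.0-fold higher number from compound 1 to compound 2 (0.48 log units; beyond the scatter), bounded by the limit of > 50000 nM in this assay, at which 1 of the 3 values shown sits. Compound 3 `Nc1nc(-c2cccs2)cn1/N=C/c1cc2ccccc2nc1Cl` differs from compound 1 by thiophen-2-yl in place of phenyl on an aromatic carbon; in this assay compound 3 gives 10300 nM, with a 1.6-fold lower number from compound 1 to compound 3 (0.20 log units; within the scatter). Compound 4 `Cc1ccc2nc(Cl)c(/C=N/n3cc(-c4cccs4)nc3N)cc2c1`, not yet measured, carries methyl in place of hydrogen on an aromatic carbon. This is the same kind of change as in compound 2, but there the methyl sits para to a large group, whereas here it sits on a fused system of two rings, meta to a fused ring and para to a fused ring. Weighing that earlier step, compound 4 is expected to show a 1.9-fold higher number from compound 3 to compound 4 (0.29 log units; within the scatter). Compound 4 is estimated at 20000 nM, between 8000 nM and 50000 nM.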

Compound 4, half-maximal inhibitory concentration: 8990 nM
Beside the measured number, compound 4's estimate is 2.2-fold (0.35 log units) above it; the range from low to high includes it.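

In this assay, the methyl on the core of compound 3 gives a 1.1-fold lower number from compound 3 to compound 4 (0.06 log units; within the scatter), so on this core the change makes no clear difference. The earlier methyl step does not match it, so in these compounds the result of adding a methyl did not carry from one core to the other: the same change on two cores in this assay, an at least 3.0-fold higher number (0.48 log units; beyond the scatter) from compound 1 to compound 2 and a 1.1-fold lower number (0.06 log units; within the scatter) from compound 3 to compound 4, at least 3.4-fold (0.54 log units) apart, beyond the scatter of two such steps. Within the data shown here, this is only one pair of steps, with the methyl in a different place in each and one step resting on a limit rather than a number, so it gives no general rule and cannot separate the role of the core from that of the position: the limit of > 50000 nM in this assay, at which 1 of the 4 values shown sits.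

As far as these compounds go, it remains open whether a methyl in the same place would behave alike on the core of compound 1. From the compounds shown here alone, it is also open how an amine or a carboxylic acid in that place would read in this assay.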